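Cytotoxicity notes: compound 3 to compound 4

The source may report more compounds than this note shows. Statements on the series, on what has been measured and on what is new or still open speak of the compounds shown alone.

Measured in a toxicity assay on NIH3T3 cells (Mus musculus) for cytotoxicity, read by resazurin assay; a higher number here means that more compound is needed for the effect, a lower number that less compound is needed:
compound 1 `COC(=O)c1ccc(NCc2cncn2Cc2ccc(C#N)cc2)cc1-c1ccccc1`: > 10000 nM
compound 2 `COC(=O)c1ccc(NCc2cncn2Cc2ccc(F)cc2F)cc1-c1ccccc1`: > 1000 nM
compound 3 `COC(=O)c1ccc(NCc2cncn2Cc2ccc(Br)cc2)cc1-c1ccccc1`: > 10000 nM

Every value for compound 1 is a limit of the assay. The value for compound 2 is likewise a limit. For compound 3 only a limit is known, sitting at the limit of > 10000 nM in this assay, at which 2 of the 3 values shown sit; compound 1 sits at the same limit, compound 2 at the limit of > 1000 nM in this assay, at which 1 of the 3 values shown sits. Accordingly a step that the two limits leave unreadable from compound 1 to compound 3 and a step that the two limits leave unreadable from compound 2 to compound 3, the steps that lead into compound 3, cannot be read, and a step that the two limits leave unreadable from compound 1 to compound 2 tells no more.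

Compound 4 `COC(=O)c1ccc(NCc2cncn2Cc2cccc(N)c2)cc1-c1ccccc1` is not yet measured in this assay. The change is 3-aminophenyl in place of 4-bromophenyl on a saturated chain carbon bound to an aromatic nitrogen. For the measured compounds named here, no measured step gives a readable size, so no movement beyond the scatter is expected; compound 4 is expected to remain at the same limit.

Compound 4 is estimated at 15000 nM, between 5000 nM and 50000 nM. The expected step is a step that the limit leaves unreadable from compound 3 to compound 4.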

Compound 4, half-maximal effective concentration: > 10000 nM
Compound 4: no number, only a limit; the forecaster's own chance of this, stated with the estimate: 85%; the middle value does not contradict the limit.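

In this assay, for the compounds shown here, compound 4 gives > 10000 nM as a limit and not a number, so no step to it from compound 1, compound 2 or compound 3 can be read. Left open is where the effect of any of these four compounds actually lies, and whether exchanging these groups changes it at all.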